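The source may hold more compounds than are shown below. What is called first, only, known or untested is meant among the compounds shown, and "the series" means these compounds.

For the measured compounds named here, compound 2 `O=C(CCC(=O)OCCCCCCSc1ccc([N+](=O)[O-])c2nonc12)Nc1ccc(F)cc1` is one of two compounds measured in an assay on isolated protein for inhibition of glutathione S-transferase P (Homo sapiens), with a stated time of 10 min (on this read-out higher numbers stand for weaker inhibition and lower numbers for stronger inhibition), where compound 2 gives 8570 nM. Going by the values given here, its only comparator, compound 1 `Cc1ccccc1NC(=O)CCC(=O)OCCCCCCSc1ccc([N+](=O)[O-])c2nonc12`, gives 4100 nM in this assay, so compound 2 stands with the higher of the two numbers, and the step of a 2.1-fold higher number from compound 1 to compound 2 (0.32 log units; beyond the scatter) is the one measured change in the set. Compound 3 `O=C(CCC(=O)OCCCCCCSc1ccc([N+](=O)[O-])c2nonc12)Nc1ccc(C(F)(F)F)cc1` differs from compound 2 in one place: trifluoromethyl in place of fluoro on an aromatic carbon, on an aromatic carbon of a six-membered aromatic ring of carbon only, para to a large group. The measured step of a 2.1-fold higher number from compound 1 to compound 2 (0.32 log units; beyond the scatter) concerns a change of the same aryl group but not the same exchange, so it bears on the new step only loosely; it suggests that changes at this ring shift this assay by modest amounts. Compound 3 is therefore expected to give about 8000 nM, within 3000 nM to 22000 nM, a step of a 1.1-fold lower number from compound 2 to compound 3 (0.03 log units; within the scatter) that is estimated to stay near the scatter.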

Compound 3, half-maximal inhibitory concentration: 5050 nM
Compound 3: middle estimate off by 1.6-fold (0.20 log units), on the high side; the range from low to high includes it.
By their numbers in this assay, from the lowest: compounds 1, 3 and 2 (each within the scatter of the next, the first and the last beyond it).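

In this assay, trifluoromethyl in place of fluoro gives a 1.7-fold lower number from compound 2 to compound 3 (0.23 log units; within the scatter), so at this aromatic carbon, para to a large group, 4 heavy atoms in place of 1 produce no step beyond the scatter. The second new step, a 1.2-fold higher number from compound 1 to compound 3 (0.09 log units; within the scatter), also stays within the scatter, so the only step beyond it among these anilide-type changes, a 2.1-fold higher number from compound 1 to compound 2 (0.32 log units; beyond the scatter), is not repeated when 4-(trifluoromethyl)phenyl replaces 2-methylphenyl. No measurement available here accounts for either step.

The compounds shown leave open how a methoxy group, an amine or a carboxylic acid at this same aromatic carbon would read out in this assay. They also leave open whether these small steps would hold with a longer chain in place of the present linker.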